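A few compounds are considered here, and "the series" means these few. Any claim that something is new, unique, unknown or untested is made for them only; others in the source may bear on it.

The measured compounds:

compound 1, `COc1cc[nH]c1/C=C1\C(=O)Nc2ccc([N+](=O)[O-])c(N3CCC(O)CC3)c21`: in a functional assay on MDA-MB-435 cells (Homo sapiens) for antiproliferative activity, read by MTT assay, with a stated time of 5 days (a lower number here means a stronger inhibitor, a higher number a weaker inhibitor), compound 1 gives 46 nM
compound 2, `COc1cc[nH]c1/C=C1\C(=O)Nc2ccc([N+](=O)[O-])c(N3CC[C@H](O)C3)c21`: compound 2 gives 104 nM
compound 3, `COc1cc[nH]c1/C=C1\C(=O)Nc2ccc([N+](=O)[O-])c(-n3ccnc3)c21`: compound 3 reaches only a limit of the assay, > 30000 nM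

Among the two numbers that are numbers, compound 1 stands lowest; its nearest neighbour is compound 2, with a 2.3-fold higher number from compound 1 to compound 2 (0.35 log units; beyond the scatter), a modest step. The value of compound 3 is a limit and not a number, at the limit of > 30000 nM in this assay, at which 1 of the 3 values shown sits; from it the step of an at least 650-fold higher number from compound 1 to compound 3 (2.81 log units; beyond the scatter) is large, as is an at least 280-fold higher number from compound 2 to compound 3 (2.46 log units; beyond the scatter).

The next compound is compound 4, `COc1cc[nH]c1/C=C1\C(=O)Nc2ccc([N+](=O)[O-])c(N3CCCC(O)C3)c21`. It differs from compound 1 as follows: 3-hydroxypiperidin-1-yl in place of 4-hydroxypiperidin-1-yl on an aromatic carbon. Within the data shown here, two measured steps bear on this change. The step of a 2.3-fold higher number from compound 1 to compound 2 (0.35 log units; beyond the scatter) shows that reshaping the hydroxylated saturated ring costs little, whereas an at least 650-fold higher number from compound 1 to compound 3 (2.81 log units; beyond the scatter) shows that replacing it with 1H-imidazol-1-yl costs a great deal. Compound 4 keeps a hydroxylated six-membered saturated ring and only relocates the hydroxyl, so the expected step in this assay is small: at most a modest rise in the number, possibly none beyond the scatter. The estimate for compound 4 is 70 nM, between 30 nM and 180 nM, which would mean an expected 1.5-fold higher number from compound 1 to compound 4 (0.18 log units; within the scatter).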

Compound 4, half-maximal inhibitory concentration: 250 nM
Estimate against measurement, compound 4: 3.6-fold (0.55 log units) below, and the stated range ends below it.
By their numbers in this assay, from the lowest: compound 1; then compound 2; then compound 4. At a limit, above all of these: compound 3.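

Among these compounds, the place of the hydroxyl on the saturated ring matters in this assay: with the same atoms joined differently, moving it from the 4-hydroxypiperidin-1-yl group to the 3-hydroxypiperidin-1-yl group gives a 5.4-fold higher number from compound 1 to compound 4 (0.74 log units; beyond the scatter), a larger step than the one the earlier change of ring produced. Keeping a six-membered ring therefore does not by itself hold the number down, since the 3-hydroxypiperidin-1-yl group also compares poorly with the 3-hydroxypyrrolidin-1-yl group, with a 2.4-fold higher number from compound 2 to compound 4 (0.38 log units; beyond the scatter). Even so, this group stays far from the 1H-imidazol-1-yl group, with an at least 120-fold lower number from compound 3 to compound 4 (2.07 log units; beyond the scatter), and that step rests on a value for compound 3 that is a limit and not a number: the limit of > 30000 nM in this assay, at which 1 of the 4 values shown sits.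

Whether the hydroxyl itself is needed stays open, since the compounds shown offer no comparison with an unsubstituted piperidin-1-yl group or a 4-aminopiperidin-1-yl group. Going by these compounds, compound 4 is also drawn without a defined configuration at the carbon bearing the hydroxyl, so whether its two mirror-image forms differ in this assay remains unknown.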